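A few compounds are considered here, and "the series" means these few. Any claim that something is new, unique, unknown or untested is made for them only; others in the source may bear on it.

Two small molecules that share a core have been tested in an ADME assay on a cell-free system (plasma, Homo sapiens) for protein binding, using equilibrium dialysis, tested at 1 mM; on this read-out lower numbers stand for a smaller free fraction and higher numbers for a larger free fraction. In this assay, compound 1 `COc1ccccc1OCCCC1CCOCC1` gives 0.106, while compound 2 `COc1ccccc1OCCOC1CCOCC1` gives 0.544. Compound 2 therefore holds the higher of the two numbers, and the gap between them lies beyond the usual scatter of repeated measurements. The two compounds do not form a simple one-place step, so their gap says little about any single change.

The next molecule, compound 3 `COc1ccccc1OCCON1CCOCC1`, is made from compound 2 by one swap: morpholin-4-yl in place of oxan-4-yl on an oxygen on a saturated carbon. The ring stays the same size and the rest of the molecule is untouched. Within the data shown here, no measured pair shows what this swap does, so the best starting point is compound 2 at 0.544, with a wide margin on either side. The estimate is a 1.0-fold higher number from compound 2 to compound 3 (0.00 log units; within the scatter), which means no expected change beyond the scatter, in either direction. For compound 3, the expected value is 0.55, within an estimated range of 0.3 to 0.8.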

Compound 3, unbound fraction in the Homo sapiens assay: 0.625
For compound 3 the middle estimate is 1.1-fold (0.06 log units) below the measured one; the measured number falls inside the stated range.
By their numbers in the Homo sapiens assay, from the lowest: compound 1; then compounds 2 and 3 (each within the scatter of the next).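

Among these compounds, in the Homo sapiens assay, compound 2 gives 0.544 and compound 3 gives 0.625; putting morpholin-4-yl in place of oxan-4-yl on an oxygen on a saturated carbon gives a 1.1-fold higher number from compound 2 to compound 3 (0.06 log units; within the scatter), the first one-place step in this set. In a physicochemical assay for solubility, in phosphate buffer, at pH 7.4 (a lower number here means a less soluble compound, a higher number a more soluble compound), compound 2 gives 275000 nM and compound 3 gives 293000 nM; the same swap gives a 1.1-fold higher number from compound 2 to compound 3 (0.03 log units; within the scatter), so neither read-out moves beyond the scatter, even though the entering ring has 2 hetero atoms and 2 hydrogen-bond acceptors where the leaving ring has 1 of each. At this position, then, the two rings cannot be told apart by either read-out, and no measurement at hand offers an explanation for that.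

As far as these compounds go, both rings are six-membered and carry no net charge, so it remains open whether a group of a different kind on the same oxygen, such as a carboxylic acid or a simple amine like dimethylamino, would leave these numbers just as steady. From the compounds shown here alone, it is also open whether the same swap would behave this way on a longer chain, or with a plain carbon in place of the oxygen that holds the ring.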